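This account rests on a few compounds, and the source may have more. Where it says the series, first, only, none or still open, it means among the compounds named here.

In an ADME assay on cells (Macrophage, Mus musculus) for cytotoxicity, read by resazurin assay, with a stated time of 3 days (on this read-out lower numbers stand for stronger inhibition and higher numbers for weaker inhibition), compound 1 (`O=C(Nc1cccc(C(F)(F)F)c1)c1cc(Cl)ccc1O`) gives 5900 nM, within the scatter of its two measured relatives: compound 2 (`O=C(Nc1ccc(C(F)(F)F)c(C(F)(F)F)c1)c1cc(Cl)ccc1O`) gives 4900 nM and compound 3 (`O=C(Nc1cccc(C(F)(F)F)c1C(F)(F)F)c1cc(Cl)ccc1O`) gives 8100 nM. Compound 4 (`N#Cc1cccc(NC(=O)c2cc(Cl)ccc2O)c1`) differs from compound 1 in one place: cyano in place of trifluoromethyl on an aromatic carbon. Going by the values given here, no measured step makes this exchange of cyano in place of trifluoromethyl. The closest evidence comes from trifluoromethyl in place of hydrogen on an aromatic carbon, which gives a 1.2-fold lower number from compound 1 to compound 2 (0.08 log units; within the scatter) and a 1.4-fold higher number from compound 1 to compound 3 (0.14 log units; within the scatter). Both steps are small, so no step beyond the scatter is expected in this assay. The expected step is a 1.2-fold higher number from compound 1 to compound 4 (0.07 log units; within the scatter). Compound 4 is estimated at 7000 nM, with an expected range of 3000 nM to 16000 nM.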

Compound 4, half-maximal inhibitory concentration: 10000 nM
Compound 4: middle estimate off by 1.4-fold (0.15 log units), on the low side; measured number inside the range.
By their numbers in this assay, from the lowest: compounds 2, 1, 3 and 4 (each within the scatter of the next, the first and the last beyond it).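

Compound 4 is the first of these compounds in which the trifluoromethyl group itself is exchanged, and not joined by a second one. In this assay, going by these compounds alone, cyano in its place gives a 1.7-fold higher number from compound 1 to compound 4 (0.23 log units; within the scatter) and stays within the scatter, so this position carries either group with no step that can be told from noise. No measurement shown here accounts for the size of this step. Going by these compounds, whether an amine or a carboxylic acid at this position would give a step beyond the scatter stays open.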